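A few compounds are considered here, and "the series" means these few. Any claim that something is new, unique, unknown or untested is made for them only; others in the source may bear on it.

Compound 1 `COc1cc(Oc2cccc(Nc3ccccc3)c2)cc(OC)c1CNCc1ccccc1`: 7490 nM
Compound 2 `COc1cc(Oc2cccc(Nc3ccccc3)c2)cc(OC)c1CNCc1ccc(F)cc1`: 6770 nM
Compound 3 `COc1cc(Oc2cccc(Nc3ccccc3)c2)cc(OC)c1CN[C@H](C)c1ccccc1`: 18700 nM

In a functional assay on SW-620 cells (Homo sapiens) for inhibition, read by MTT assay, with a stated time of 72 h (a higher number here means a weaker inhibitor, a lower number a stronger inhibitor), the highest of the three numbers belongs to compound 3. Both steps leading to it are modest: a 2.5-fold higher number from compound 1 to compound 3 (0.40 log units; beyond the scatter), and a 2.8-fold higher number from compound 2 to compound 3 (0.44 log units; beyond the scatter). Compound 4 `COc1cc(Oc2cccc(Nc3ccccc3)c2)cc(OC)c1CN(C)C` has dimethylamino in place of (1-phenylethyl)amino on a saturated chain carbon bound to an aromatic carbon. For the measured compounds named here, no measured step makes this exact change. Adding a methyl raised the number in a 2.5-fold higher number from compound 1 to compound 3 (0.40 log units; beyond the scatter), and compound 4 lacks that methyl. Adding fluoro barely registered in a 1.1-fold lower number from compound 1 to compound 2 (0.04 log units; within the scatter). Losing the whole ring remains untested, so the range stays wide. A modest move to a lower number is expected, a 2.1-fold lower number from compound 3 to compound 4 (0.32 log units; beyond the scatter). For compound 4 the estimated value is 9000 nM, with an expected range from 3500 nM to 22000 nM.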

Compound 4, half-maximal inhibitory concentration: > 20000 nM
Compound 4 ended at the assay's limit (the forecaster's own chance of this, stated with the estimate: 8%); middle value at least 2.2-fold (0.34 log units) from the limit.
By their numbers in this assay, from the lowest: compounds 2 and 1 (each within the scatter of the next); then compound 3. At a limit, above all of these: compound 4.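

In this assay, compound 4 sits at a limit of the assay, not at a true number: the limit of > 20000 nM in this assay, at which 1 of the 4 values shown sits. Replacing the benzylamino and (4-fluorobenzyl)amino groups with dimethylamino, which has no ring, weakens inhibition beyond the scatter, giving an at least 2.6-fold higher number from compound 1 to compound 4 (0.42 log units; beyond the scatter) and an at least 2.9-fold higher number from compound 2 to compound 4 (0.47 log units; beyond the scatter). Against compound 3 the floor settles nothing, at an at least 1.0-fold higher number from compound 3 to compound 4 (0.02 log units; that floor lies within the scatter), so the earlier methyl effect cannot be set against the loss of the ring.

As far as these compounds go, it remains open whether the ring itself matters or simply the size of the group. A piperidine or a 2-phenylethylamino group on this carbon could help separate the two.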